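The source may hold more compounds than are shown below. What is called first, only, known or untested is meant among the compounds shown, and "the series" means these compounds.

Of the compounds shown here, three sharing one core have been measured in an assay on isolated protein for inhibition of DNA topoisomerase 1 (Homo sapiens), with a stated time of 30 min, tested at 100 uM; on this read-out lower numbers stand for a weaker effect and higher numbers for a stronger effect at the one concentration tested. Compound 2 `Oc1ccc(-c2cc(-c3ccccc3)nc(-c3ccc(Cl)cc3)c2)cc1` gives 68% and stands highest of the three. Compound 1 `Oc1ccc(-c2cc(-c3ccncc3)nc(-c3ccccc3Cl)c2)cc1` gives 9.9% in this assay, and compound 3 `Oc1ccc(-c2cc(-c3ccccc3)nc(-c3cccc(Cl)c3)c2)cc1` gives 0%. Among the compounds with values here, the only step that changes a single group is the one from compound 2 to compound 3, where a number 68 percentage points lower from compound 2 to compound 3 (beyond the scatter); that step moves the chlorine on its ring and says nothing directly about the change considered here.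

Compound 4 `Oc1ccc(-c2cc(-c3ccncc3)nc(-c3ccc(Cl)cc3)c2)cc1` is compound 2 with one group exchanged: pyridin-4-yl in place of phenyl on an aromatic carbon. Within the data shown here, no measured pair differs only in this way. Compound 1 also carries a pyridin-4-yl group, but it differs from compound 2 in two places at once, so its low value in this assay cannot be laid to either change alone. The step from compound 2 to compound 4 is therefore open; the small set shows that single changes on this core can swing the read-out widely, so a drop beyond the scatter seems more likely than none, but its size is uncertain. Compound 4 is expected to show a number 28 percentage points lower from compound 2 to compound 4 (beyond the scatter), giving an estimated 40% in this assay, within a range from 5% to 75%.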

Compound 4, a percentage reported as inhibition, at one concentration (the size of the read-out at that concentration, not a potency): 5.9%
For compound 4 the middle estimate is 34.1 percentage points above the measured one; the range from low to high includes it.
By their numbers in this assay, from the lowest: compounds 3, 4 and 1 (each within the scatter of the next); then compound 2.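

In this assay, exchanging phenyl for pyridin-4-yl at this position, with the 4-chlorophenyl group left as it is, gives a number 62.1 percentage points lower from compound 2 to compound 4 (beyond the scatter), so this single change is enough to lose nearly all of the high read-out of compound 2. The chlorine position does not separate the two pyridin-4-yl compounds, since 4-chlorophenyl in place of 2-chlorophenyl gives a number 4 percentage points lower from compound 1 to compound 4 (within the scatter), and the low value of compound 1 no longer needs its 2-chlorophenyl group to account for it. The data offer no measurement that could explain why a ring nitrogen in this group has such an effect on the read-out.

The compounds shown leave open whether the high read-out depends on an unchanged phenyl ring here or would survive another group at this position, such as a 4-aminophenyl group, a 4-carboxyphenyl group or a simple methyl group. Going by these compounds, it also remains open how a 2-chlorophenyl group would behave alongside phenyl, and, with only one concentration tested, how these read-outs would translate into potency.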